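Lengthening the chain beyond the chloro group in compound 3

This account rests on a few compounds, and the source may have more. Where it says the series, first, only, none or still open, it means among the compounds named here.

Measured compounds:
compound 1 `CCCCCC(=O)Nc1ccc(S(=O)(=O)Oc2ccccc2I)cc1`, 9600 nM
compound 2 `CC(C)C(=O)Nc1ccc(S(=O)(=O)Oc2ccccc2I)cc1`, 3300 nM
compound 3 `O=C(CCl)Nc1ccc(S(=O)(=O)Oc2ccccc2I)cc1`, 600 nM

All three share one core and differ only in the group on the carbonyl carbon of the amide. In a functional assay on HT-1080 cells (Homo sapiens) for antiproliferative activity, read by sulforhodamine B assay, with a stated time of 48 h (on this read-out lower numbers stand for stronger inhibition and higher numbers for weaker inhibition), compound 3 gives the lowest number of the three: compound 2 sits higher by a 5.5-fold lower number from compound 2 to compound 3 (0.74 log units; beyond the scatter), and compound 1 sits higher still by a 16-fold lower number from compound 1 to compound 3 (1.20 log units; beyond the scatter). Both steps lie beyond the scatter, so compound 3 is the most potent of the measured set.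

Compound 4 `O=C(CCCCl)Nc1ccc(S(=O)(=O)Oc2ccccc2I)cc1` keeps the core and the amide but carries 2-chloroethyl in place of chloro on a saturated chain carbon bound to a carbonyl carbon. The chloro group thus moves outward along a longer chain, so the change reads from chloromethyl to 3-chloropropyl on the carbonyl carbon.

Within the data shown here, two measured steps bear on this. Going from compound 1 to compound 3 replaced butyl with chloro and lowered the number by a 16-fold lower number from compound 1 to compound 3 (1.20 log units; beyond the scatter); going from compound 2 to compound 3 gave a 5.5-fold lower number from compound 2 to compound 3 (0.74 log units; beyond the scatter). In both, a longer or branched chain went with a higher number than the short chloro-bearing group. Compound 4 restores chain length, so a modest rise in this assay is expected, a 5.0-fold higher number from compound 3 to compound 4 (0.70 log units; beyond the scatter), landing compound 4 nearer compound 2 than compound 3.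

Compound 4 is therefore estimated at 3000 nM, within 800 nM to 12000 nM.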

Compound 4, half-maximal inhibitory concentration: 12000 nM
Compound 4: middle estimate off by 4.0-fold (0.60 log units), on the low side, and the stated range covers the measured number.
By their numbers in this assay, from the lowest: compound 3; then compound 2; then compounds 1 and 4 (each within the scatter of the next).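

In this assay, the chloro group alone does not secure the low number: replacing it with 2-chloroethyl on a saturated chain carbon bound to a carbonyl carbon gives a 20-fold higher number from compound 3 to compound 4 (1.30 log units; beyond the scatter) and so loses the advantage of the short chloromethyl group. Among these compounds, at this longer length, the chlorine no longer sets the compound apart from the plain chain, since chloro in place of ethyl gives a 1.3-fold higher number from compound 1 to compound 4 (0.10 log units; within the scatter) and the two compounds cannot be told apart in this test. The branched isopropyl group also compares favourably with 3-chloropropyl, as the change to 3-chloropropyl on the carbonyl carbon gives a 3.6-fold higher number from compound 2 to compound 4 (0.56 log units; beyond the scatter) and shows that a chlorine-bearing chain need not beat a chain without chlorine.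

No measurement shown explains why chloromethyl stands apart from the longer chain.

The compounds shown leave open how the number changes with the intermediate 2-chloroethyl group on the carbonyl carbon, and whether the low number depends on chlorine itself, which bromomethyl or plain methyl on that carbon would help to test.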